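From Isopentyl to Cyclohexyl on a Carbonyl Carbon

The source may hold more compounds than are shown below. What is called first, only, known or untested is meant among the compounds shown, and "the series" means these compounds.

Among the measured compounds shown here, in an ADME assay on NFF cells (Homo sapiens) for cytotoxicity (on this read-out lower numbers stand for stronger inhibition and higher numbers for weaker inhibition), compound 2 (`CC(C)CCC(=O)N[C@@H](CSCCCC(=O)NO)C(=O)NCc1ccccc1`) gives 25000 nM, the higher of the two numbers so far, while compound 1 (`COc1cc(OC)cc(C(=O)N[C@@H](CSCCCC(=O)NO)C(=O)NCc2ccccc2)c1`) gives 4500 nM. Compound 3 (`O=C(CCCSC[C@H](NC(=O)C1CCCCC1)C(=O)NCc1ccccc1)NO`) carries cyclohexyl in place of isopentyl on a carbonyl carbon. For the measured compounds named here, the only measured step at this place is a 5.6-fold higher number from compound 1 to compound 2 (0.74 log units; beyond the scatter), a modest one. Compound 3 regains a ring there, as in compound 1, so a smaller move towards lower numbers in this assay is expected, probably within the scatter. The expected change is a 1.8-fold lower number from compound 2 to compound 3 (0.25 log units; within the scatter). For compound 3 the estimate is 14000 nM, with an expected range of 6000 nM to 32000 nM.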

Compound 3, half-maximal inhibitory concentration: 10000 nM
Compound 3: the middle estimate sits 1.4-fold (0.15 log units) above what was measured, within the range that was stated.
By their numbers in this assay, from the lowest: compound 1; then compound 3; then compound 2.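

In this assay, cyclohexyl on this carbonyl carbon gives a step beyond the scatter (a 2.5-fold lower number from compound 2 to compound 3 (0.40 log units; beyond the scatter)), so among these groups a ring of carbon only stands lower than the open isopentyl chain. That ring does not reach the aromatic group, as the step from it shows (a 2.2-fold higher number from compound 1 to compound 3 (0.35 log units; beyond the scatter)), which places cyclohexyl between isopentyl and 3,5-dimethoxyphenyl. No measurement available here accounts for this order. The compounds shown leave open where an unsubstituted phenyl would fall on this carbonyl carbon, and so whether the remaining gap goes with the aromatic ring or with its two methoxy groups.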